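A few compounds are considered here, and "the series" means these few. Any claim that something is new, unique, unknown or untested is made for them only; others in the source may bear on it.

Measured so far in an assay for displacement of a labelled ligand from Sigma non-opioid intracellular receptor 1 (Cavia porcellus), read by scintillation counting, with a stated time of 180 min; a lower number here means a stronger inhibitor, a higher number a weaker inhibitor:
compound 1, `Cn1ncc2c1CCOC21CCN(N2CCC(c3ccccc3)CC2)CC1`: 7 nM
compound 2, `CCCCN1CCC2(CC1)OC(OC)Cc1c2cnn1-c1ccccc1`: 8 nM
compound 3, `COC1Cc2c(cnn2C)C2(CCN(Cc3ccc(F)cc3)CC2)O1`: 21 nM

Compound 3 gives the highest of the three numbers in this assay; its gaps to compound 2 and to compound 1 both lie beyond the scatter, so compound 3 reads as the weakest of the three. Compound 4, `CCCN1CCC2(CC1)OC(OC)Cc1c2cnn1C`, has not yet been measured. It differs from compound 3 in one place: ethyl in place of 4-fluorophenyl on a saturated chain carbon bound to an amine nitrogen in a ring. Within the data shown here, compound 2 gives a low number in this assay but differs from compound 4 in more than one place, so no single measured step leads to compound 4. The change is expected to give a higher number, a step beyond the scatter: a 4.8-fold higher number from compound 3 to compound 4 (0.68 log units; beyond the scatter). Compound 4 is estimated at 100 nM, in the range 25 nM to 500 nM.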

Compound 4, inhibition constant: > 1000 nM
Compound 4: no number, only a limit (the forecaster's own chance of this, stated with the estimate: 5%); middle value at least 10-fold (1.00 log units) away from the limit.
By their numbers in this assay, from the lowest: compounds 1 and 2 (each within the scatter of the next); then compound 3. At a limit, above all of these: compound 4.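

Compound 4 gives > 1000 nM in this assay as a limit of the assay and not a number. Ethyl in place of 4-fluorophenyl on a saturated chain carbon bound to an amine nitrogen in a ring gives an at least 47-fold higher number from compound 3 to compound 4 (1.67 log units; beyond the scatter) and is a large step. Among these compounds, this position is thus sensitive to the change, which the earlier compounds could not show, having no one-place step among them. Open, on these data alone, is whether the loss follows the fluorine or the whole aromatic ring. A plain phenyl or a cyclohexyl at this place would separate the two.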